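Compound 3 to compound 4: phenyl to 4-acetamidophenyl

The source may report more compounds than this note shows. Statements on the series, on what has been measured and on what is new or still open speak of the compounds shown alone.

In a functional assay on SMMC-7721 cells (Homo sapiens) for cytotoxicity, read by MTT assay, with a stated time of 24 h (on this read-out higher numbers stand for weaker inhibition and lower numbers for stronger inhibition), compound 3 `O=C1/C(=C/c2cccnc2)CN(S(=O)(=O)c2ccccc2)C/C1=C\c1ccccc1C(F)(F)F` gives 10900 nM and lies within the scatter of compound 2 `O=C1/C(=C/c2cccnc2)CN(S(=O)(=O)c2ccccc2)C/C1=C\c1ccccc1F` at 19100 nM while compound 1 `CN1C/C(=C\c2cccnc2)C(=O)/C(=C/c2ccccc2C(F)(F)F)C1` at 3900 nM stands beyond the scatter from compound 3. Compound 4 `CC(=O)Nc1ccc(S(=O)(=O)N2C/C(=C\c3cccnc3)C(=O)/C(=C/c3ccccc3C(F)(F)F)C2)cc1` differs from compound 3 by acetamido in place of hydrogen on an aromatic carbon as acetamido in place of hydrogen on an aromatic carbon, para to a large group. Going by the values given here, no measured step touches that carbon. The nearest evidence is a 2.8-fold higher number from compound 1 to compound 3 (0.45 log units; beyond the scatter) for the change on the amine nitrogen and a 1.8-fold lower number from compound 2 to compound 3 (0.24 log units; within the scatter) for the change from fluoro to trifluoromethyl, and neither sets a direction here. The expected change is a 1.1-fold lower number from compound 3 to compound 4 (0.04 log units; within the scatter) and no step beyond the scatter is expected. For compound 4 the estimated value is 10000 nM with an expected range from 4000 nM to 25000 nM as a working figure.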

Compound 4, half-maximal inhibitory concentration: 9830 nM
Compound 4: the middle estimate sits 1.0-fold (0.01 log units) above what was measured, and the stated range covers the measured number.
By their numbers in this assay, from the lowest: compound 1; then compounds 4, 3 and 2 (each within the scatter of the next).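

In this assay, going by these compounds alone, the first change at this carbon, acetamido in place of hydrogen para to a large group, stays within the scatter (a 1.1-fold lower number from compound 3 to compound 4 (0.04 log units; within the scatter)). The earlier steps shown here concerned the amine nitrogen and the fluoro to trifluoromethyl change, whereas this one shows that the carbon accepts an acetamido group with no step beyond the scatter. No measurement on hand accounts for this result.

From the compounds shown here alone, whether an amine, a carboxylic acid or a longer chain on this carbon would stay within the scatter remains open. So does the reading for acetamido on the other carbons of this ring.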